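The compounds below may be only part of what the source reports. "The series", "measured", "known", "first", "only" and "open" are said of these compounds alone.

Working notes on the series. Compound 1 `O=C(CN1CCCC1)N1CCC(NS(=O)(=O)c2cc(S(=O)(=O)c3ccccc3)ccc2C(F)(F)F)CC1` gives 110 nM in an assay on isolated protein for binding affinity to secreted frizzled-related protein 1 (Homo sapiens), read by fluorescence; on this read-out lower numbers stand for stronger inhibition and higher numbers for weaker inhibition. Compound 2 `CC(C)(C)OC(=O)N1CCC[C@H]1C(=O)N1CCC(NS(=O)(=O)c2cc(S(=O)(=O)c3ccccc3)ccc2C(F)(F)F)CC1` gives 60 nM in this assay, the step being a 1.8-fold lower number from compound 1 to compound 2 (0.26 log units; within the scatter). Compound 3 `CN(C)c1ccc(C(=O)N2CCC[C@H]2C(=O)N2CCC(NS(=O)(=O)c3cc(S(=O)(=O)c4ccccc4)ccc3C(F)(F)F)CC2)cc1` gives 110 nM in this assay, with the step of a 1.8-fold higher number from compound 2 to compound 3 (0.26 log units; within the scatter). Compound 3 therefore sits level with compound 1 at the digits shown, the two together the highest of the three numbers, and compound 2 is the furthest from it while still within the scatter. Compound 4 `CC(C)(C)CCN1CCC[C@H]1C(=O)N1CCC(NS(=O)(=O)c2cc(S(=O)(=O)c3ccccc3)ccc2C(F)(F)F)CC1` carries 3,3-dimethylbutyl in place of (4-(dimethylamino)phenyl)carbonyl on an amine nitrogen in a ring. Both measured steps changed a group on a carbonyl carbon in this part of the series and neither went beyond the scatter, so the step from compound 3 to compound 4 is expected to stay within it as well: a 1.1-fold lower number from compound 3 to compound 4 (0.04 log units; within the scatter). Compound 4 is expected at 100 nM, with a range of 40 nM to 300 nM in this assay.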

Compound 4, half-maximal inhibitory concentration: 30 nM
Estimate against measurement, compound 4: 3.3-fold (0.52 log units) above; measured number below the stated range.
By their numbers in this assay, from the lowest: compounds 4, 2, 1 and 3 (each within the scatter of the next, the first and the last beyond it).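

For the compounds shown here, on the amine nitrogen of the five-membered ring, 3,3-dimethylbutyl gives the first step beyond the scatter in this part of the series (a 3.7-fold lower number from compound 3 to compound 4 (0.56 log units; beyond the scatter)), and the step from the pyrrolidin-1-ylmethyl amide is the same size (a 3.7-fold lower number from compound 1 to compound 4 (0.56 log units; beyond the scatter)). Against tert-butoxycarbonyl the same group stays within the scatter (a 2.0-fold lower number from compound 2 to compound 4 (0.30 log units; within the scatter)), so a carbonyl on this nitrogen is not shown to be needed. Nothing available explains these steps.

Still open, as far as these compounds go, is how a 4-(dimethylamino)benzyl group would read here, which would separate the carbonyl from the aromatic ring. From the compounds shown here alone, a shorter chain such as ethyl, or the free ring amine, is also open.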